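A few compounds are considered here, and "the series" means these few. Any claim that something is new, unique, unknown or untested is made for them only; others in the source may bear on it.

Compound 1 `CCOC(=O)N1CCC(=NNC(=O)c2ccc(C)cc2)CC1`: > 400000 nM
Compound 2 `O=C(NN=C1CC(c2ccccc2)NC(c2ccccc2)C1)c1ccccc1`: > 400000 nM

In a toxicity assay on BJ cells (Homo sapiens) for cytotoxicity, read by MTT assay, with a stated time of 24 h (on this read-out higher numbers stand for weaker inhibition and lower numbers for stronger inhibition), compound 1 gives > 400000 nM, which is a limit of the assay and not a number. In this assay compound 2 likewise gives only a limit, > 400000 nM. Where compound 2 stands is therefore described only by the limit of > 400000 nM in this assay, at which 2 of the 2 values shown sit, so no number is known for it at all.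

Compound 3 `O=C(NN=C1CC(c2ccccc2)NC(c2ccccc2)C1)c1ccc(F)cc1` differs from compound 2 by fluoro in place of hydrogen on an aromatic carbon. Going by the values given here, no step between two measured compounds is available to size this change, so what follows is expectation only. Nothing in the two values at hand points toward a shift beyond the usual scatter, and the most likely outcome is that compound 3 again reaches only the limit. The step from compound 2 to compound 3 is thus estimated as a number no higher from compound 2 to compound 3 (the limit leaves the size open). Compound 3 is accordingly expected to give about 400000 nM in this assay, with a range from 150000 nM to 1000000 nM.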

Compound 3, half-maximal inhibitory concentration: > 400000 nM
Compound 3: a limit, no number (the forecaster's own chance of this, stated with the estimate: 85%); the middle value lies on the limit itself.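

Compound 2 and compound 3 both stand at a limit and not at a number, so no step can be read between them: the limit of > 400000 nM in this assay, at which 3 of the 3 values shown sit. The compounds shown leave open what number any of them would give in this assay, and whether fluoro in place of hydrogen on an aromatic carbon shifts it.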